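Working notes: from compound 1 to compound 3

The source may hold more compounds than are shown below. What is called first, only, known or untested is meant among the compounds shown, and "the series" means these compounds.

Measured so far:
compound 1 `O=C1CCc2cc(OCc3nnc(SCc4ccc(C(F)(F)F)cc4)o3)ccc2N1` gives 23.1 mg/kg
compound 2 `CCCCCSc1nnc(COc2ccc(NC(C)=O)cc2)o1` gives 22.6 mg/kg

In a functional assay on the whole organism (strain Kunming) with Mus musculus as the target, with a stated time of 30 min (on this read-out higher numbers stand for an effect only at larger amounts of compound and lower numbers for an effect already at smaller amounts), compound 1 stands at the highest of the two numbers, with compound 2 lying within the scatter of it. Compound 3 `CCCCCSc1nnc(COc2ccc3c(c2)CCC(=O)N3)o1` has not been measured. It differs from compound 1 in one place: butyl in place of 4-(trifluoromethyl)phenyl on a saturated chain carbon bound to a sulfur. No step between measured compounds is available, so nothing shown points to a change beyond the scatter. For compound 3 the step of a 1.1-fold lower number from compound 1 to compound 3 (0.02 log units; within the scatter) is expected to be small, in no clear direction, because compound 2 gives 22.6 mg/kg. Compound 3 is expected at 22 mg/kg, with a range from 12 mg/kg to 45 mg/kg.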

Compound 3, dose for half-maximal effect: 8.9 mg/kg
For compound 3 the middle estimate is 2.5-fold (0.39 log units) above the measured one; measured number below the stated range.
By their numbers in this assay, from the lowest: compound 3; then compounds 2 and 1 (each within the scatter of the next).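

Going to butyl in place of 4-(trifluoromethyl)phenyl on a saturated chain carbon bound to a sulfur gives a 2.6-fold lower number from compound 1 to compound 3 (0.41 log units; beyond the scatter) in this assay and so shows that the number responds to the group at this position. The six-membered aromatic ring of compound 1 is not required there for an effect at the smaller amounts seen with compound 3. Nothing at hand accounts for the step.

Open, on these data alone, is whether an octyl chain would lower the number further or raise it again. Also open, as far as these compounds go, is whether a plain phenyl group would read like compound 1, which would separate the ring from the trifluoromethyl group.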